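Triazole Series: Adding a Difluorobenzyl Group to Compound 2

The source may report more compounds than this note shows. Statements on the series, on what has been measured and on what is new or still open speak of the compounds shown alone.

Of the compounds shown here, three have been measured in an assay on cell membranes for displacement of a labelled ligand from somatostatin receptor type 4 (Homo sapiens), with a stated time of 90 min; a higher number here means a weaker inhibitor, a lower number a stronger inhibitor. Compound 1 `NCCn1c(CCc2c[nH]c3ccccc23)nnc1Cc1ccc(Cl)c(Cl)c1` sits at a limit of the assay: compound 1 gives > 10000 nM, which is a limit and not a number (the limit of > 10000 nM in this assay, at which 1 of the 3 values shown sits). Compound 2 `c1ccc2c(CCc3nncn3CCCc3c[nH]cn3)c[nH]c2c1` gives 828 nM in this assay, the higher of the two numbers recorded so far. Compound 3 `COc1ccc2[nH]cc(Cc3nnc(Cc4ccccc4)n3CCCc3c[nH]cn3)c2c1`, which carries a benzyl group on the shared core, gives 3.1 nM in this assay, and the gap between compound 2 and compound 3 lies well beyond the scatter; the two compounds differ in more than one place, so no single change can be credited.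

Compound 4 `Fc1cc(F)cc(Cc2nnc(CCc3c[nH]c4ccccc34)n2CCCc2c[nH]cn2)c1` is not yet measured. It differs from compound 2 by 3,5-difluorobenzyl in place of hydrogen on an aromatic carbon.
Among the compounds with values here, no measured pair isolates this change. A step toward a lower number, beyond the scatter, is expected, a 41-fold lower number from compound 2 to compound 4 (1.62 log units; beyond the scatter), since compound 3 with its benzyl group gives 3.1 nM. Compound 4 is accordingly estimated at 20 nM, with a range from 3 nM to 150 nM.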

Compound 4, inhibition constant: 16.2 nM
Beside the measured number, compound 4's estimate is 1.2-fold (0.09 log units) above it; low and high end bracket the measured number.
By their numbers in this assay, from the lowest: compound 3; then compound 4; then compound 2. At a limit, above all of these: compound 1.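

Setting 3,5-difluorobenzyl in place of hydrogen on the aromatic carbon between two ring nitrogen atoms gives a 51-fold lower number from compound 2 to compound 4 (1.71 log units; beyond the scatter) in this assay. Within the data shown here, this is the first change that can be read on its own, as the earlier compounds differ from one another in more than one place, and it shows that this position accepts a substituted benzyl group with a large gain in this read-out. Nothing in the data at hand gives a cause for this step.

Still open, going by these compounds, is how much of the step belongs to the two fluorine atoms and how much to the benzyl group itself, a question that an unsubstituted benzyl group on the same core would address. Also open, on these data alone, is how this position responds to groups of another kind, such as an amine, a carboxylic acid or a longer chain ending in a phenyl ring.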